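The compounds below may be only part of what the source reports. "The series", "measured", "known", "first", "only" and "open" are said of these compounds alone.

Compound 3 `Cn1c(=O)c(S(=O)(=O)c2ccc(F)cc2F)cc2cnc(Nc3ccc4sccc4c3)nc21` carries a 1-benzothiophen-5-yl group on a nitrogen on an aromatic ring of the shared core. In a functional assay on DU-145 cells (Homo sapiens) for inhibition, read by trypan blue exclusion, with a stated time of 72 h (on this read-out higher numbers stand for weaker inhibition and lower numbers for stronger inhibition), compound 3 gives 500 nM, level at the digits shown with compound 1 `Cn1c(=O)c(S(=O)(=O)c2ccc(F)cc2)cc2cnc(Nc3cnc4[nH]ccc4c3)nc21`, which gives 500 nM, and together these two are the lowest of the three numbers. Compound 2 `Cn1c(=O)c(S(=O)(=O)c2ccc(F)cc2F)cc2cnc(Nc3ccc4cccc(O)c4n3)nc21` gives 5000 nM. Among the compounds with values here, the only measured step at that nitrogen is a 10-fold lower number from compound 2 to compound 3 (1.00 log units; beyond the scatter); it concerns a different pair of groups and so bears on compound 4 only in showing that exchange of the group at that nitrogen can move the number well beyond the scatter. Compound 4 `Cn1c(=O)c(S(=O)(=O)c2ccc(F)cc2F)cc2cnc(Nc3cnc4[nH]ccc4c3)nc21` differs from compound 3 by a group of 9 heavy atoms (7 carbon, 2 nitrogen; one five-membered aromatic ring with 1 hetero atom, one six-membered aromatic ring with 1 hetero atom) in place of a group of 9 heavy atoms (8 carbon, 1 sulfur; one five-membered aromatic ring with 1 hetero atom, one six-membered aromatic ring of carbon only), on a nitrogen on an aromatic ring. Compound 1, which gives 500 nM, carries the group that enters in compound 4 and differs from it elsewhere, and its number does not differ from that of compound 3 at the digits shown. The expected step is therefore no change at the digits printed from compound 3 to compound 4 (within the scatter), nothing beyond the scatter. Compound 4 is estimated at 500 nM, with a range from 200 nM to 1500 nM.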

Compound 4, half-maximal inhibitory concentration: 750 nM
Compound 4: the middle estimate sits 1.5-fold (0.18 log units) below what was measured, within the range that was stated.
By their numbers in this assay, from the lowest: compounds 1, 3 and 4 (each within the scatter of the next); then compound 2.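

In this assay, a 1.5-fold higher number from compound 3 to compound 4 (0.18 log units; within the scatter) shows that the two groups cannot be told apart at this nitrogen, although the entering group counts 1 hydrogen-bond donor and 1-benzothiophen-5-yl counts 0. The second exchange at this nitrogen, a 6.7-fold lower number from compound 2 to compound 4 (0.82 log units; beyond the scatter), lies beyond the scatter, so the 8-hydroxyquinolin-2-yl group now stands apart from two other groups rather than one. Outside this nitrogen, a 1.5-fold higher number from compound 1 to compound 4 (0.18 log units; within the scatter) gives the first reading of fluoro in place of hydrogen on an aromatic carbon, and that change stays within the scatter.

No supporting data bear on why these numbers fall as they do. Still open, from the compounds shown here alone, is how the number responds to an amine or a carboxylic acid on the group at this nitrogen.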